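A few compounds are considered here, and "the series" means these few. Any claim that something is new, unique, unknown or untested is made for them only; others in the source may bear on it.

Measured compounds:
compound 1 `O=C1O[C@@H](CN2CCCCC2)CN1c1ccc(-n2cc(-c3ccccn3)cn2)c(F)c1` gives 3.1 in a physicochemical assay for lipophilicity, read by HPLC, measured as octanol-water partition; a lower number here means a more polar compound, a higher number a more lipophilic compound;
compound 2 `CCNC(=O)NC[C@H]1CN(c2ccc(-n3cc(-c4ccccn4)cn3)c(F)c2)C(=O)O1` gives 2.45 in this assay;
compound 3 `O=C(NC[C@H]1CN(c2ccc(-n3cc(-c4ccccn4)cn3)c(F)c2)C(=O)O1)C(F)F` gives 1.9 in this assay.

Compound 3 stands lowest of the three; the nearest is compound 2, the furthest compound 1. The steps run a number 0.65 log units lower from compound 1 to compound 2 (beyond the scatter) and a number 1.20 log units lower from compound 1 to compound 3 (beyond the scatter), both from a common starting point, and between the two amide-type analogues a number 0.55 log units lower from compound 2 to compound 3 (beyond the scatter).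

Compound 4 `CONC(=O)[C@H]1CN(c2ccc(-n3cc(-c4ccccn4)cn3)c(F)c2)C(=O)O1` is not yet measured in this assay. Its change from compound 3 is methoxycarbamoyl in place of (((difluoromethyl)carbonyl)amino)methyl on a saturated ring carbon. Among the measured compounds shown here, none of the measured steps covers this change directly: all three vary what sits on the chain carbon, whereas here the methylene is lost and the group moves onto the ring carbon itself. The measured steps show that exchanges at this position move this assay by modest to large amounts, with compound 3 already at the low end. A further small downward move, or none beyond the scatter, is the expectation. The expected step is a number 0.10 log units lower from compound 3 to compound 4 (within the scatter). Compound 4 is estimated at 1.8, with a range from 1.3 to 2.4.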

Compound 4, partition coefficient: >= 1.58
Compound 4 ended at the assay's limit (the forecaster's own chance of this, stated with the estimate: 0%); the middle value does not contradict the limit.
By their numbers in this assay, from the lowest: compound 3; then compound 2; then compound 1.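

Compound 4 stands at a limit of this assay, not at a number: the limit of >= 1.58 in this assay, at which 1 of the 4 values shown sits. The steps to compound 4 from compound 1, compound 2 and compound 3 cannot be read. The compounds shown leave open how methoxycarbamoyl on the saturated ring carbon compares with the three groups it replaces.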